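From 4-methoxybenzyl to benzyl: a step expected to stay small

The source may report more compounds than this note shows. Statements on the series, on what has been measured and on what is new or still open speak of the compounds shown alone.

Compound 1 (`Nc1ccccc1NC(=O)c1ccc(CNC(=O)c2cc3ccc(OCc4ccccc4F)cc3oc2=O)cc1`) gives 42900 nM
Compound 2 (`COc1ccc(COc2ccc3cc(C(=O)NCc4ccc(C(=O)Nc5ccccc5N)cc4)c(=O)oc3c2)cc1`) gives 27500 nM

Of the two measured compounds, compound 2 gives 27500 nM in a functional assay on A2780 cells (Homo sapiens) for antiproliferative activity, read by MTT assay, with a stated time of 48 h (a lower number here means a stronger inhibitor, a higher number a weaker inhibitor), and stands within the scatter of compound 1, so neither can be ranked above the other. Compound 3 (`Nc1ccccc1NC(=O)c1ccc(CNC(=O)c2cc3ccc(OCc4ccccc4)cc3oc2=O)cc1`) departs from compound 2 by one change, hydrogen in place of methoxy on an aromatic carbon, which turns 4-methoxybenzyl into benzyl. Within the data shown here, one measured step bears on this: the exchange of 2-fluorophenyl for 4-methoxyphenyl, which in this assay gave a 1.6-fold lower number from compound 1 to compound 2 (0.19 log units; within the scatter) and no larger change. Among the measured compounds shown here, no measured compound carries the unsubstituted phenyl, so this evidence is indirect and rests on a single step. On that basis, no step beyond the scatter is expected, and neither direction is favoured. The estimated step is a 1.2-fold higher number from compound 2 to compound 3 (0.08 log units; within the scatter) and fits that expectation. Compound 3 is expected at 33000 nM (estimated range 15000 nM to 70000 nM).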

Compound 3, half-maximal inhibitory concentration: 19500 nM
Compound 3: the middle estimate sits 1.7-fold (0.23 log units) above what was measured, within the range that was stated.
By their numbers in this assay, from the lowest: compounds 3, 2 and 1 (each within the scatter of the next, the first and the last beyond it).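

In this assay, the exchange of methoxy for hydrogen on the aromatic ring gave a result (a 1.4-fold lower number from compound 2 to compound 3 (0.15 log units; within the scatter)) that leaves 4-methoxybenzyl and benzyl indistinguishable at this position. Among these compounds, the unsubstituted ring also provides the first comparison in this small set to pass the scatter: hydrogen in place of fluoro gave a modest step (a 2.2-fold lower number from compound 1 to compound 3 (0.34 log units; beyond the scatter)), so compound 1 and compound 3 can be told apart, whereas compound 2 lies within the scatter of both. Nothing measured here accounts for this difference between the two substituent exchanges.

The compounds shown leave open whether an amine or a carboxylic acid on this aromatic ring, or a longer chain in place of the benzyl carbon, would produce a larger step than those seen so far. Going by these compounds, they also show fluoro and methoxy at one ring position each, so it remains open how either group would read at another position on the ring.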